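From 4-Fluorophenyl to Ethyl on a Ret V804M Inhibitor

The source may report more compounds than this note shows. Statements on the series, on what has been measured and on what is new or still open speak of the compounds shown alone.

Compound 1 `CC(C)n1nc(-c2cc(-c3ccccc3)on2)c2c(N)ncnc21`: 4970 nM
Compound 2 `CC(C)n1nc(-c2cc(-c3ccc(F)cc3)on2)c2c(N)ncnc21`: > 10000 nM

In an assay on BaF3 cells for inhibition of proto-oncogene tyrosine-protein kinase receptor Ret variant V804M (Homo sapiens), read by MTT assay, with a stated time of 48 h (on this read-out higher numbers stand for weaker inhibition of growth and lower numbers for stronger inhibition of growth), compound 1 gives 4970 nM. For compound 2 the result > 10000 nM is a limit of this assay, not a number, as shown by the limit of > 10000 nM in this assay, at which 1 of the 2 values shown sits. For the measured compounds named here, the only measured step is an at least 2.0-fold higher number from compound 1 to compound 2 (0.30 log units; that floor lies within the scatter), which adds a single fluorine. Compound 3 `CCc1cc(-c2nn(C(C)C)c3ncnc(N)c23)no1` differs from compound 2 by ethyl in place of 4-fluorophenyl on an aromatic carbon. Going by the values given here, no measured step covers trading an aromatic ring for a short chain, so the direction is open. Compound 3 is expected to give 8000 nM, within 2000 nM to 30000 nM. That estimate implies a step of an at least 1.2-fold lower number from compound 2 to compound 3 (0.09 log units; that floor lies within the scatter).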

Compound 3, concentration for 50% growth inhibition: 5770 nM
Compound 3: the middle estimate sits 1.4-fold (0.14 log units) above what was measured, and the stated range covers the measured number.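

In this assay ethyl, which has no ring, does as well as phenyl on this aromatic carbon next to the ring oxygen, with a 1.2-fold higher number from compound 1 to compound 3 (0.06 log units; within the scatter). Replacing 4-fluorophenyl with ethyl gives an at least 1.7-fold lower number from compound 2 to compound 3 (0.23 log units; that floor lies within the scatter). That step is only a floor, and the value of compound 2 is a limit of the assay, not a number: the limit of > 10000 nM in this assay, at which 1 of the 3 values shown sits. On these data alone, whether a longer chain such as butyl, an amine or a carboxylic acid at this position would shift the number beyond the scatter remains open.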